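The compounds below may be only part of what the source reports. "The series", "measured", "known", "first", "only" and "open" are said of these compounds alone.

Measured in a functional assay on A549 cells (Homo sapiens) for inhibition, read by CCK-8 assay, with a stated time of 72 h, tested at 1 uM; a higher number here means more inhibition of growth at the concentration tested, a lower number less inhibition of growth:
compound 1 `COC(=O)c1ccc(NC(=O)C2(C(=O)Nc3ccc(Nc4ncc5cc(C(=O)N(C)C)n(C6CCCC6)c5n4)cc3)CC2)cc1` gives 77.1%
compound 2 `Cc1ccc(NC(=O)C2(C(=O)Nc3ccc(Nc4ncc5cc(C(=O)N(C)C)n(C6CCCC6)c5n4)cc3)CC2)cc1` gives 40.2%
compound 3 `CN(C)C(=O)c1cc2cnc(Nc3ccc(NC(=O)C4(C(=O)Nc5cccc(C#N)c5)CC4)cc3)nc2n1C1CCCC1` gives 70.8%

Compound 3 stands level with compound 1 within the scatter, a number 6.3 percentage points lower from compound 1 to compound 3 (within the scatter), and well clear of compound 2, a number 30.6 percentage points higher from compound 2 to compound 3 (beyond the scatter).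

Compound 4 `COC(=O)c1cccc(NC(=O)C2(C(=O)Nc3ccc(Nc4ncc5cc(C(=O)N(C)C)n(C6CCCC6)c5n4)cc3)CC2)c1` is the next case. The change is methoxycarbonyl in place of cyano on an aromatic carbon, meta to a large group. Among the compounds with values here, no measured pair makes this exact swap. The nearest evidence is the small step of a number 6.3 percentage points lower from compound 1 to compound 3 (within the scatter), which exchanges 4-(methoxycarbonyl)phenyl for 3-cyanophenyl and so links the same two groups, though at different places on the ring. The large step of a number 36.9 percentage points lower from compound 1 to compound 2 (beyond the scatter) concerns methyl, which does not enter here. Compound 1 and compound 3 thus give no sign of a gap between methoxycarbonyl and cyano, and no step beyond the scatter is expected. The estimated step is a number 1.2 percentage points higher from compound 3 to compound 4 (within the scatter). For compound 4 the expected value is 72%, within an estimated range of 57% to 85%.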

Compound 4, percent growth inhibition at one concentration: 10.5%
Compound 4: the middle estimate sits 61.5 percentage points above what was measured; the measured number lies below the stated range.
By their numbers in this assay, from the lowest: compound 4; then compound 2; then compounds 3 and 1 (each within the scatter of the next).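

Methoxycarbonyl and cyano are not interchangeable at this position of the ring on the amide-type nitrogen: in this assay the swap gives a number 60.3 percentage points lower from compound 3 to compound 4 (beyond the scatter). The place of the ester on the ring matters strongly, as 3-(methoxycarbonyl)phenyl in place of 4-(methoxycarbonyl)phenyl gives a number 66.6 percentage points lower from compound 1 to compound 4 (beyond the scatter), so the level numbers of compound 1 and compound 3 did not reflect a general match between the two groups. Compound 4 also falls short of the 4-methylphenyl compound, with a number 29.7 percentage points lower from compound 2 to compound 4 (beyond the scatter), so here methoxycarbonyl goes with the lowest number in the set rather than the highest.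

Still open, from the compounds shown here alone, is whether a carboxylic acid or a primary amide in place of methoxycarbonyl at this position would stay as low as compound 4 or return towards compound 3. Nothing available explains the loss seen with compound 4.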